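Trading an indole for phenyl on a shared core

A few compounds are considered here, and "the series" means these few. Any claim that something is new, unique, unknown or untested is made for them only; others in the source may bear on it.

In a functional assay on B16-F0 cells (Mus musculus) for inhibition, read by CCK-8 assay, with a stated time of 48 h (a higher number here means a weaker inhibitor, a lower number a stronger inhibitor), compound 2 (`COc1cc(-c2ccnc3cc(-c4c[nH]c5ccccc45)nn23)cc(OC)c1OC`) gives 40 nM and sits within the scatter of compound 3 (`COc1cc(-c2ccnc3cc(-c4ccc(C)cc4)nn23)cc(OC)c1OC`) at 21 nM in the same test. Compound 1 (`COc1cc(-c2cc3nccc(-c4c[nH]c5ccccc45)n3n2)cc(OC)c1OC`) returns only a limit (> 10000 nM). Compound 4 (`COc1cc(-c2ccnc3cc(-c4ccccc4)nn23)cc(OC)c1OC`) differs from compound 2 in one place (phenyl in place of 1H-indol-3-yl on an aromatic carbon): phenyl in place of 1H-indol-3-yl on an aromatic carbon. Among the compounds with values here, one measured step bears on this, with 4-methylphenyl in place of 1H-indol-3-yl on an aromatic carbon: a 1.9-fold lower number from compound 2 to compound 3 (0.28 log units; within the scatter) in size. One step is thin support, but no change beyond the scatter is therefore expected in this assay here. The expected step is a 1.1-fold lower number from compound 2 to compound 4 (0.06 log units; within the scatter) in size. For compound 4 the estimate is 35 nM with an expected range from 10 nM to 120 nM in this test.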

Compound 4, half-maximal inhibitory concentration: 4730 nM
Estimate against measurement, compound 4: 140-fold (2.13 log units) below; measured number above the stated range.
By their numbers in this assay, from the lowest: compounds 3 and 2 (each within the scatter of the next); then compound 4. At a limit, above all of these: compound 1.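

On an aromatic carbon of this five-membered ring, phenyl is no stand-in for 1H-indol-3-yl: in this assay this change gives a 120-fold higher number from compound 2 to compound 4 (2.07 log units; beyond the scatter) and marks a real loss. The methyl of compound 3 carries much of the difference, as hydrogen in place of methyl gives a 230-fold higher number from compound 3 to compound 4 (2.35 log units; beyond the scatter) on an otherwise identical structure. Nothing shown here gives a cause for this sensitivity.

From the compounds shown here alone, whether an ethyl chain, a chlorine or an amine in place of that methyl would hold the low number remains open.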